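The source may report more compounds than this note shows. Statements on the series, on what has been measured and on what is new or still open speak of the compounds shown alone.

Measured so far: compound 3 `Clc1ccccc1/C=N/Nc1nc2ccccc2nc1Cc1ccccc1` with 5.8 nM; compound 2 `Clc1ccc(/C=N/Nc2nc3ccccc3nc2Cc2ccccc2)cc1` with 76 nM; compound 1 `COc1ccc(/C(C)=N/Nc2nc3ccccc3nc2Cc2ccccc2)cc1` with 89 nM.

In an assay on isolated protein for inhibition of Amine oxidase [flavin-containing] A (Homo sapiens), read by spectrophotometry (a higher number here means a weaker inhibitor, a lower number a stronger inhibitor), compound 3 gives the lowest number of the three, and the step from compound 2 to compound 3, a 13-fold lower number from compound 2 to compound 3 (1.12 log units; beyond the scatter), shows that moving the chlorine on the ring produced a large gain. Compound 4 `C/C(=N\Nc1nc2ccccc2nc1Cc1ccccc1)c1ccccc1` changes the same part of the molecule: a group of 9 heavy atoms (8 carbon, 1 nitrogen; one six-membered aromatic ring of carbon only) in place of a group of 9 heavy atoms (7 carbon, 1 nitrogen, 1 chlorine; one six-membered aromatic ring of carbon only), on a nitrogen on an aromatic ring. The entering group carries no chlorine at all, so the gain seen in a 13-fold lower number from compound 2 to compound 3 (1.12 log units; beyond the scatter) is unlikely to carry over, and the values of compound 1 and compound 2, which also lack that chlorine placement, suggest where compound 4 may land. Compound 4 is therefore expected to give a number close to those two, a step of about a 12-fold higher number from compound 3 to compound 4 (1.08 log units; beyond the scatter) from compound 3, estimated at 70 nM (range 20 nM to 250 nM).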

Compound 4, half-maximal inhibitory concentration: 79 nM
Compound 4: the middle estimate sits 1.1-fold (0.05 log units) below what was measured; the range from low to high includes it.
By their numbers in this assay, from the lowest: compound 3; then compounds 2, 4 and 1 (each within the scatter of the next).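

In this assay, hydrogen in place of methoxy leaves no readable difference, with a 1.1-fold lower number from compound 1 to compound 4 (0.05 log units; within the scatter). Compound 4 carries no chlorine, yet it sits level with the 4-chlorophenyl compound, with a 1.0-fold higher number from compound 2 to compound 4 (0.02 log units; within the scatter), whereas a 14-fold higher number from compound 3 to compound 4 (1.13 log units; beyond the scatter) leaves the 2-chlorophenyl compound alone among the four, so having a chlorine does not set it apart, only having it in that placement. No measurement here explains why that placement matters.

Still open, going by these compounds, is whether a bromine or an amine in the chlorine's place would match compound 3. On these data alone, it is also open whether the chlorine's gain would hold with the extra methyl of compound 4 present.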